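A few compounds are considered here, and "the series" means these few. Any claim that something is new, unique, unknown or untested is made for them only; others in the source may bear on it.

Working notes on a shared core, taken from compound 1 `Cc1ccc(NC2=CC(=O)c3nc4n(c3C2=O)[C@H]2OC[C@@H](O)[C@H]2OC4)cc1`, with the group on the double-bonded ring carbon varied. Among the measured compounds shown here, in a functional assay on MCF7 cells (Homo sapiens) for inhibition, read by sulforhodamine B assay (on this read-out lower numbers stand for stronger inhibition and higher numbers for weaker inhibition), compound 1 gives 1660 nM, the only number among the three values shown. Compound 2 `O=C1C(Nc2ccc(C(F)(F)F)cc2)=CC(=O)c2c1nc1n2[C@H]2OC[C@@H](O)[C@H]2OC1` reaches only a limit in this assay, > 4000 nM. Compound 3 `CCCN(CCC)C1=CC(=O)c2c(nc3n2[C@H]2OC[C@@H](O)[C@H]2OC3)C1=O` likewise returns a limit in this assay, > 16000 nM. Compound 4 `O=C1C=C(N2CCC2)C(=O)c2c1nc1n2[C@H]2OC[C@@H](O)[C@H]2OC1` differs from compound 1 by azetidin-1-yl in place of (4-methylphenyl)amino on a double-bonded ring carbon. For the measured compounds named here, no measured step covers this change. Compound 3, whose amine also lacks an aromatic ring, sits at the limit of > 16000 nM in this assay, at which 1 of the 3 values shown sits, so a loss beyond the scatter is expected. The expected step is a 6.0-fold higher number from compound 1 to compound 4 (0.78 log units; beyond the scatter). Compound 4 is expected to give 10000 nM, between 3000 nM and 40000 nM, with a fair chance of a limit only.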

Compound 4, half-maximal inhibitory concentration: > 16000 nM
Compound 4 was reported as a limit; the forecaster's own chance of this, stated with the estimate: 55%; middle value at least 1.6-fold (0.20 log units) from the limit.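

In this assay, among the compounds shown here, azetidin-1-yl in place of (4-methylphenyl)amino on this double-bonded ring carbon gives an at least 9.6-fold higher number from compound 1 to compound 4 (0.98 log units; beyond the scatter) in the first readable step at this position. From the compounds shown here alone, compound 4 gives > 16000 nM as a limit, so the true size of this step remains unknown. Compound 4 now sits at the same limit as compound 3, and neither carries an aromatic ring in this group: the limit of > 16000 nM in this assay, at which 2 of the 4 values shown sit.

Which part of the (4-methylphenyl)amino group matters remains open, as the loss of the ring and of the amine hydrogen are not separated here. Benzylamino, unsubstituted phenylamino and N-methyl-(4-methylphenyl)amino would each bear on that question.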